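A few compounds are considered here, and "the series" means these few. Any claim that something is new, unique, unknown or untested is made for them only; others in the source may bear on it.

Working notes on the series. In a functional assay on MCF7 cells (Homo sapiens) for antiproliferative activity, read by MTT assay, with a stated time of 72 h (on this read-out lower numbers stand for stronger inhibition and higher numbers for weaker inhibition), compound 1 (`CC1=CC[C@H]2[C@H](CC[C@]2(C)O)C(C)(C)[C@@H]1CC[C@H]1[C@]2(C)CC[C@H](OC(=O)c3ccc(C)cc3)C(C)(C)O[C@H]2CC[C@@]1(C)O`) gives > 50000 nM, which is a limit and not a number. In this assay, compound 2 (`CC1=CC[C@H]2[C@H](CC[C@]2(C)O)C(C)(C)[C@@H]1CC[C@H]1[C@]2(C)CC[C@H](OC(=O)c3ccc(C(F)(F)F)c(F)c3)C(C)(C)O[C@H]2CC[C@@]1(C)O`) gives > 50000 nM, again only a limit. The series therefore stands so far at the limit of > 50000 nM in this assay, at which 2 of the 2 values shown sit. Within the data shown here, the one measured step is a step that the two limits leave unreadable from compound 1 to compound 2, and it offers neither a size nor a direction to carry forward.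

The next change leads to compound 3 (`CC1=CC[C@H]2[C@H](CC[C@]2(C)O)C(C)(C)[C@@H]1CC[C@H]1[C@]2(C)CC[C@H](OC(=O)c3ccco3)C(C)(C)O[C@H]2CC[C@@]1(C)O`), with furan-2-yl in place of 3-fluoro-4-(trifluoromethyl)phenyl on a carbonyl carbon. Among the measured compounds shown here, the data hold no measured step for this exchange, and no numerical value for any compound. The expectation therefore rests on compound 2, which sits at the limit > 50000 nM. No clear step in either direction is expected in this assay, and the most likely report is again a limit. The expected step is a number no higher from compound 2 to compound 3 (the limit leaves the size open), and this remains an estimate only. The estimated value for compound 3 is 50000 nM, with an expected range from 20000 nM to 100000 nM.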

Compound 3, half-maximal inhibitory concentration: 25700 nM
The estimate for compound 3 lay 1.9-fold (0.29 log units) above the measured number; the range from low to high includes it.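

In this assay, this place on a carbonyl carbon now yields a first readable number: furan-2-yl in place of 3-fluoro-4-(trifluoromethyl)phenyl gives an at least 1.9-fold lower number from compound 2 to compound 3 (0.28 log units; that floor lies within the scatter). Furan-2-yl in place of 4-methylphenyl gives an at least 1.9-fold lower number from compound 1 to compound 3 (0.28 log units; that floor lies within the scatter); the true size of both steps stays open, their floors lie within the scatter, and the step between the two aryl compounds, compound 1 and compound 2, still cannot be read. The series as a whole still rests largely on a single limit, which is not a number: the limit of > 50000 nM in this assay, at which 2 of the 3 values shown sit.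

Furan-2-yl differs from both phenyl groups at once in ring size, in its ring hetero atom and hydrogen-bond acceptor, and in its smaller count of heavy atoms, so compound 3 alone does not tell which of these differences goes with the readable number. Open questions remain for thiophen-2-yl, with sulfur as the ring hetero atom, for a pyridine ring, for an unsubstituted phenyl group and for a plain butyl chain on the same carbonyl carbon, each of which would separate these differences in this assay.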